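A few compounds are considered here, and "the series" means these few. Any claim that something is new, unique, unknown or untested is made for them only; others in the source may bear on it.

Measured so far in a functional assay on HCT-116 cells (Homo sapiens) for cytotoxicity, read by sulforhodamine B assay, with a stated time of 24 h; a lower number here means a stronger inhibitor, a higher number a weaker inhibitor:
- compound 1 `O=C1Nc2ccc(S(=O)(=O)N3CCOCC3)cc2/C1=N/NC(=O)c1ccccc1` gives 28900 nM
- compound 2 `N#CCC(=O)N/N=C1\C(=O)Nc2ccc(S(=O)(=O)N3CCOCC3)cc21` gives 10300 nM
- compound 3 `O=C1Nc2ccc(S(=O)(=O)N3CCOCC3)cc2/C1=N/c1ccc(O)cc1` gives 27300 nM

Compound 3 holds the second highest of the three numbers. Its nearest neighbour is compound 1, with a 1.1-fold lower number from compound 1 to compound 3 (0.02 log units; within the scatter) separating them; its furthest is compound 2, with a 2.7-fold higher number from compound 2 to compound 3 (0.42 log units; beyond the scatter) between them. The step that does stand out in this small set is a 2.8-fold lower number from compound 1 to compound 2 (0.45 log units; beyond the scatter), which swaps the group on the carbonyl carbon of the hydrazide arm, not anything on the aryl ring.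

Compound 4 `O=C1Nc2ccc(S(=O)(=O)N3CCOCC3)cc2/C1=N/c1ccc(C(=O)O)cc1` differs from compound 3 by carboxy in place of hydroxy on an aromatic carbon. None of the three measured steps alters a substituent on that aromatic ring; all three exchange the whole group attached to the double-bonded nitrogen or the carbonyl substituent. For the measured compounds named here, there is therefore no measured step that bears directly on the hydroxy-to-carboxy exchange, and the best guide is the flatness of the numbers around compound 3 itself.

The expected step is a 1.0-fold lower number from compound 3 to compound 4 (0.00 log units; within the scatter), taken as no change beyond the scatter. Compound 4 is expected near 27000 nM, within 10000 nM to 80000 nM.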

Compound 4, half-maximal inhibitory concentration: 23600 nM
For compound 4 the middle estimate is 1.1-fold (0.06 log units) above the measured one; the range from low to high includes it.
By their numbers in this assay, from the lowest: compound 2; then compounds 4, 3 and 1 (each within the scatter of the next).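

In this assay, the only exchange shown on the aromatic ring itself stays within the scatter (a 1.2-fold lower number from compound 3 to compound 4 (0.06 log units; within the scatter)), so hydroxy and carboxy, para to a large group, cannot be told apart here. The 4-carboxyphenyl group likewise cannot be told apart from benzamido on the double-bonded nitrogen (a 1.2-fold lower number from compound 1 to compound 4 (0.09 log units; within the scatter)), while the ((cyanomethyl)carbonyl)amino group remains the only one set apart from the others (a 2.3-fold higher number from compound 2 to compound 4 (0.36 log units; beyond the scatter)). No measurement at hand accounts for these numbers.

On these data alone, whether an amine, a methoxy group or a chlorine atom at this aromatic carbon would give a step beyond the scatter stays open. Also open, as far as these compounds go, is whether a longer chain in place of cyanomethyl on the carbonyl carbon would keep, widen or lose the separation seen for compound 2.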